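The compounds below may be only part of what the source reports. "The series", "measured", "known", "first", "only" and "open" are said of these compounds alone.

Measured in a functional assay on A549 cells (Homo sapiens) for inhibition, read by sulforhodamine B assay; on this read-out lower numbers stand for stronger inhibition of growth and higher numbers for weaker inhibition of growth:
Compound 1 `Oc1cccc2[nH]c(-c3ccc(-c4ccc(-c5ccc(OC(F)(F)F)cc5)cc4)cc3)nc12`: 190 nM
Compound 2 `Oc1ccc(-c2ccc(-c3ccc(-c4nc5c(O)cccc5[nH]4)cc3)cc2)cc1`: 170 nM

Among the compounds with values here, compound 1, at 190 nM, has the higher of only two numbers, but it lies within the scatter of compound 2, so it holds no distinct rank.

Next in line is compound 3 `Cc1ccc2[nH]c(-c3ccc(-c4ccc(-c5ccc(OC(F)(F)F)cc5)cc4)cc3)nc2c1`, not yet measured in this assay. The change from compound 1 is 5-methyl-1H-benzimidazol-2-yl in place of 4-hydroxy-1H-benzimidazol-2-yl on an aromatic carbon: 5-methyl-1H-benzimidazol-2-yl in place of 4-hydroxy-1H-benzimidazol-2-yl.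

Within the data shown here, only one measured step is available, a 1.1-fold lower number from compound 1 to compound 2 (0.05 log units; within the scatter). It lies within the scatter and concerns a different place in the molecule, so it shows only that this one replacement left the number unmoved. Among the measured compounds shown here, no measured compound lacks the 4-hydroxy group or carries the methyl group, so the data give no direct guide to size or direction. A modest move towards a higher number is a tentative expectation, and no change beyond the scatter remains possible. The expected step is a 2.1-fold higher number from compound 1 to compound 3 (0.32 log units; beyond the scatter). For compound 3 the estimate is 400 nM, with an expected range of 110 nM to 1500 nM.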

Compound 3, concentration for 50% growth inhibition: 3560 nM
Beside the measured number, compound 3's estimate is 8.9-fold (0.95 log units) below it, and the stated range ends below it.
By their numbers in this assay, from the lowest: compounds 2 and 1 (each within the scatter of the next); then compound 3.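

In this assay, 5-methyl-1H-benzimidazol-2-yl in place of 4-hydroxy-1H-benzimidazol-2-yl gives a 19-fold higher number from compound 1 to compound 3 (1.27 log units; beyond the scatter), so this part of the molecule shows a large change beyond the scatter, whereas the earlier replacement on the other end of the molecule gave only a 1.1-fold lower number from compound 1 to compound 2 (0.05 log units; within the scatter). The change is not a single one: the hydroxy group leaves, a methyl group enters, the substituent's place in the name differs, and the entering group counts fewer hydrogen-bond donors and acceptors than the leaving one, so this step alone cannot assign the rise in the number to any one of these. No measurement is at hand that explains the rise.

Open, as far as these compounds go, is whether the hydroxy group itself is what keeps the number low, or whether an amine or a methoxy group in its place on the same ring would serve equally. Also open, from the compounds shown here alone, is whether the same replacement would give a step of similar size on the core of compound 2, which carries a hydroxy group in place of the trifluoromethoxy end.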